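Shifting One Chlorine Substituent Toward Compound 4

The source may hold more compounds than are shown below. What is called first, only, known or untested is meant among the compounds shown, and "the series" means these compounds.

Of the compounds shown here, three sharing one core have been measured in an assay on liver (Sus scrofa) for inhibition of glucose-6-phosphatase catalytic subunit 1 (Homo sapiens), using microsomes; on this read-out lower numbers stand for stronger inhibition and higher numbers for weaker inhibition. Compound 1 `C(=N/N(Cc1ccccc1)Cc1ccccc1)\c1ccccc1` gives 1500 nM in this assay. Compound 2 `Clc1ccc(/C=N/N(Cc2ccccc2)Cc2ccccc2)cc1` gives 240 nM in this assay, and the step of a 6.3-fold lower number from compound 1 to compound 2 (0.80 log units; beyond the scatter) is a modest gain. Compound 3 `Clc1cc(Cl)cc(/C=N/N(Cc2ccccc2)Cc2ccccc2)c1` gives only a limit of the assay in this assay, > 100000 nM, so its true number is not known; it sits at the limit of > 100000 nM in this assay, at which 1 of the 3 values shown sits. Its steps are an at least 66-fold higher number from compound 1 to compound 3 (1.82 log units; beyond the scatter) and an at least 410-fold higher number from compound 2 to compound 3 (2.61 log units; beyond the scatter), both large losses.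

Compound 4 `Clc1ccc(/C=N/N(Cc2ccccc2)Cc2ccccc2)cc1Cl` has not been measured. The change is 3,4-dichlorophenyl in place of 3,5-dichlorophenyl on a carbon with a double bond to nitrogen. One chlorine keeps the position seen in compound 2, while the other stays at a position shared with compound 3. The step from compound 2 to compound 3 shows that placing two chlorines at the positions of compound 3 destroys the activity seen with one chlorine, so compound 4 is expected to sit between compound 2 and the limit of compound 3. Compound 4 is therefore expected to give about 3000 nM in this assay, within 300 nM to 60000 nM. The expected step is an at least 33-fold lower number from compound 3 to compound 4 (1.52 log units; beyond the scatter), a gain from the limit, though the chance that only a limit is reported again remains real.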

Compound 4, half-maximal inhibitory concentration: 2000 nM
Compound 4: the middle estimate sits 1.5-fold (0.18 log units) above what was measured, and the stated range covers the measured number.
By their numbers in this assay, from the lowest: compound 2; then compounds 1 and 4 (each within the scatter of the next). At a limit, above all of these: compound 3.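

Rearranging the same atoms, from 3,5-dichlorophenyl to 3,4-dichlorophenyl on a carbon with a double bond to nitrogen, restores measurable inhibition in this assay, an at least 50-fold lower number from compound 3 to compound 4 (1.69 log units; beyond the scatter), so carrying a second chlorine does not by itself abolish activity; where the chlorines sit decides the outcome. The value of compound 3 is a limit of the assay and not a number: the limit of > 100000 nM in this assay, at which 1 of the 4 values shown sits.

The second chlorine still brings no benefit, since adding it costs inhibition, an 8.3-fold higher number from compound 2 to compound 4 (0.92 log units; beyond the scatter), and the comparison with the bare phenyl ring shows no real difference, a 1.3-fold higher number from compound 1 to compound 4 (0.12 log units; within the scatter).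

Only chlorine and hydrogen appear on this ring in the compounds shown, so it stays open how a fluorine, a methoxy group or a carboxylic acid would fare there. Also open, going by these compounds, is how a single chlorine would fare at the place it holds in compound 3 and compound 4 but not in compound 2.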